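The compounds below may be only part of what the source reports. "The series", "measured", "known", "first", "only" and "open" are said of these compounds alone.

In a functional assay on PANC-1 cells (Homo sapiens) for inhibition, read by MTT assay, with a stated time of 24 h (a higher number here means a weaker inhibitor, a lower number a stronger inhibitor), compound 3 `COc1ccccc1-n1cc(CN2C(=O)C[C@@H]3CC[C@@]2(C)C3(C)C)nn1` gives 120 nM, within the scatter of compound 2 `CC1(C)[C@H]2CC[C@]1(C)N(Cc1cn(-c3ccccc3C#N)nn1)C(=O)C2` at 240 nM, while compound 1 `CC1(C)[C@H]2CC[C@]1(C)N(Cc1cn(-c3ccccc3Br)nn1)C(=O)C2` gives 280 nM. The measured steps are all small: a 1.2-fold lower number from compound 1 to compound 2 (0.07 log units; within the scatter), a 2.0-fold lower number from compound 2 to compound 3 (0.30 log units; within the scatter) and a 2.3-fold lower number from compound 1 to compound 3 (0.37 log units; beyond the scatter). Compound 4 `CC1(C)[C@H]2CC[C@]1(C)N(Cc1cn(-c3cccc(O)c3)nn1)C(=O)C2` brings a different kind of change: 3-hydroxyphenyl in place of 2-methoxyphenyl on an aromatic nitrogen. The three measured steps swap methoxy, cyano and bromo on an aromatic carbon, and none of them involves a 3-hydroxyphenyl group, so they guide the size of the next step only loosely. In this assay, the expected step is modest, toward a higher number and not beyond the scatter: a 1.7-fold higher number from compound 3 to compound 4 (0.22 log units; within the scatter). For compound 4 the estimate is 200 nM, with an expected range of 70 nM to 600 nM.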

Compound 4, half-maximal inhibitory concentration: 280 nM
Estimate against measurement, compound 4: 1.4-fold (0.15 log units) below; measured number inside the range.
By their numbers in this assay, from the lowest: compounds 3, 2, 1 and 4 (each within the scatter of the next, the first and the last beyond it).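

In this assay the change to 3-hydroxyphenyl on the aromatic nitrogen gives a 2.3-fold higher number from compound 3 to compound 4 (0.37 log units; beyond the scatter) against 2-methoxyphenyl, yet a 1.2-fold higher number from compound 2 to compound 4 (0.07 log units; within the scatter) against 2-cyanophenyl and no change at the digits printed from compound 1 to compound 4 (within the scatter) against 2-bromophenyl. This position therefore accepts a group with a hydrogen-bond donor without leaving the range of compound 1 and compound 2, and only compound 3 stands apart from compound 4. Nothing available explains this step.

Still open, from the compounds shown here alone, is whether the hydroxy group itself or its place on the phenyl ring carries the step, and how a phenyl bearing an amine or a carboxylic acid would read here.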